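Swapping Bromo for Methyl on the Indole Ring

The source may hold more compounds than are shown below. What is called first, only, known or untested is meant among the compounds shown, and "the series" means these compounds.

Three compounds share a core in which a cyclic imide is attached to a bicyclic aromatic system, and they differ only in the group placed on the six-membered ring. Compound 2 `O=C1CC(c2c[nH]c3cc(Br)ccc23)C(=O)N1` carries a bromo group and, in an assay on isolated protein for inhibition of Indoleamine 2,3-dioxygenase 1 (Homo sapiens), with a stated time of 15 min (a lower number here means a stronger inhibitor, a higher number a weaker inhibitor), compound 2 gives 420 nM, the lowest of the two numbers reported. Compound 1 `O=C1CC(c2c[nH]c3ccc(C(F)(F)F)cc23)C(=O)N1` carries a trifluoromethyl group, and in this assay compound 1 gives 9700 nM. Compound 3 `COc1ccc2c(C3CC(=O)NC3=O)c[nH]c2c1` carries a methoxy group; for compound 3 this assay reports only a limit, > 50000 nM, so its number is not known (the limit of > 50000 nM in this assay, at which 1 of the 3 values shown sits). Within the data shown here, the one step between neighbours, an at least 110-fold higher number from compound 2 to compound 3 (2.07 log units; beyond the scatter), is large.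

Compound 4 `Cc1ccc2c(C3CC(=O)NC3=O)c[nH]c2c1` differs from compound 2 by methyl in place of bromo on an aromatic carbon. Among the measured compounds shown here, only the step from compound 2 to compound 3 bears on this change, and it was large; the incoming methyl, like the outgoing bromo, brings no hydrogen-bond donor or acceptor, so a smaller loss is expected. For compound 4 in this assay the estimate is 1500 nM, expected between 500 nM and 6000 nM, a step of a 3.6-fold higher number from compound 2 to compound 4 (0.55 log units; beyond the scatter).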

Compound 4, half-maximal inhibitory concentration: 54000 nM
Compound 4: middle estimate off by 36-fold (1.56 log units), on the low side; measured number above the stated range.
By their numbers in this assay, from the lowest: compound 2; then compound 1; then compound 4.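

With methyl in place of bromo there is a 130-fold higher number from compound 2 to compound 4 (2.11 log units; beyond the scatter), even though the two groups match in their counts of heavy atoms, hydrogen-bond donors and hydrogen-bond acceptors. Before this result, the large loss on going to methoxy could have been tied to the oxygen that group brings, but methyl brings no oxygen and the loss is still large, so an incoming oxygen is not needed for it. Compound 3 has only a limit in this assay, so its step to compound 4 cannot be read, and the two replacements cannot be ranked: the limit of > 50000 nM in this assay, at which 1 of the 4 values shown sits.

As far as these compounds go, whether chloro, iodo or a nitrile at this position would keep a number close to that of compound 2 remains open. The compounds shown also do not explain why bromo and methyl differ so widely here.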